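A few compounds are considered here, and "the series" means these few. Any claim that something is new, unique, unknown or untested is made for them only; others in the source may bear on it.

Measured compounds:
Compound 1, `CC(C)(C)[C@H](C(=O)Nc1ncc(Br)s1)c1ccc(Cl)cc1`: in a functional assay on CHO cells for agonist activity at Free fatty acid receptor 2 (Homo sapiens), read by cAMP accumulation (on this read-out lower numbers stand for stronger inhibition and higher numbers for weaker inhibition), compound 1 gives 700 nM.
Compound 2, `CSc1cnc(NC(=O)[C@H](c2ccc(Cl)cc2)C(C)(C)C)s1`: in this assay compound 2 gives 500 nM.

Compound 2 carries the lower of the two numbers, though the margin lies within the scatter: a 1.4-fold lower number from compound 1 to compound 2 (0.15 log units; within the scatter). Compound 3, `CC(C)(C)[C@H](C(=O)Nc1ncc(Cc2ccc(Cl)cc2)s1)c1ccc(Cl)cc1`, is not yet measured. It differs from compound 2 in one place: 4-chlorobenzyl in place of methylsulfanyl on an aromatic carbon. For the measured compounds named here, the one measured step, from compound 1 to compound 2, exchanged one group for another on an aromatic carbon and moved the number within the scatter. No measured pair shows what bringing a 4-chlorobenzyl group into that position does, so these data give no direction for the step from compound 2 to compound 3 and no reason to expect a change beyond the scatter. On that basis the number for compound 3 is expected to stay near that of compound 2, with a wide range on either side; the expected step is a 1.1-fold lower number from compound 2 to compound 3 (0.05 log units; within the scatter). The estimate for compound 3 in this assay is 450 nM, with a range from 90 nM to 2500 nM.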

Compound 3, half-maximal inhibitory concentration: 25000 nM
Beside the measured number, compound 3's estimate is 56-fold (1.74 log units) below it; measured number above the stated range.
By their numbers in this assay, from the lowest: compounds 2 and 1 (each within the scatter of the next); then compound 3.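

In this assay, the aromatic carbon next to the ring sulfur proves not to be indifferent to the group it carries. Bromo and methylsulfanyl sit within the scatter of each other there, whereas 4-chlorobenzyl brings a 50-fold higher number from compound 2 to compound 3 (1.70 log units; beyond the scatter) and a 36-fold higher number from compound 1 to compound 3 (1.55 log units; beyond the scatter), so this position can respond strongly to a change of group, with the number moving towards weaker inhibition. The new group adds a six-membered aromatic ring and more heavy atoms in a single exchange, and no measurement at hand accounts for the jump.

The compounds shown leave open whether the higher number follows from the benzyl ring itself, from its chlorine or from the carbon that links it to the core, a question on which an unsubstituted benzyl or a phenyl group would bear. Also open, as far as these compounds go, is how an amine, a methoxy group or a short alkyl chain would read at this place, and whether any group here would move the number of compound 2, 500 nM, downward beyond the scatter.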